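The source may report more compounds than this note shows. Statements on the series, on what has been measured and on what is new or still open speak of the compounds shown alone.

Working notes on the series in a functional assay on MCF7 cells (Homo sapiens) for inhibition, read by MTT assay, with a stated time of 2 days; on this read-out higher numbers stand for weaker inhibition and lower numbers for stronger inhibition.

Of the compounds shown here, three have been measured. Compound 1 `Nc1ccccc1/C=C/c1cccc(O)c1` gives 17 ug/mL in this assay. Compound 2 `Nc1cccc(/C=C/c2ccccc2O)c1` gives 24.7 ug/mL in this assay, and compound 3 `COc1cccc(/C=C/c2ccccc2O)c1` gives 18 ug/mL in this assay. All three numbers lie within the scatter of one another, so no order among them can be read from these data: compound 1 stands closest to compound 3 and furthest from compound 2, but neither gap is beyond the scatter.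

Compounds 1 and 2 are built from the same atoms joined differently; the difference between the two cores is not broken down here.

Compound 3 differs from compound 2 by methoxy in place of amino on an aromatic carbon
This gave a 1.4-fold lower number from compound 2 to compound 3 (0.14 log units; within the scatter).

Compound 4 `COc1ccccc1/C=C/c1cccc(O)c1` has not yet been measured in this assay. It differs from compound 1 by methoxy in place of amino on an aromatic carbon
This is the same kind of change as that from compound 2 to compound 3, not the same change: in compound 4 the entering group sits ortho to a group of 9 heavy atoms, whereas in compound 3 it sits meta to a group of 9 heavy atoms.

Going by the values given here, the expectation for compound 4 rests on the single earlier instance of this kind of change, where compound 3 gave 18 ug/mL against compound 2 giving 24.7 ug/mL. The expected step is a 1.2-fold lower number from compound 1 to compound 4 (0.08 log units; within the scatter), kept within the scatter because a 1.4-fold lower number from compound 2 to compound 3 (0.14 log units; within the scatter) was itself within the scatter. Compound 4 is therefore estimated to give about 14 ug/mL in this assay, with 7 ug/mL and 28 ug/mL as the expected lower and upper ends.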

Compound 4, half-maximal inhibitory concentration: 24.3 ug/mL
For compound 4 the middle estimate is 1.7-fold (0.24 log units) below the measured one, within the range that was stated.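

Methoxy in place of amino on an aromatic carbon, here ortho to a group of 9 heavy atoms, gave a 1.4-fold higher number from compound 1 to compound 4 (0.16 log units; within the scatter) in this assay. Set beside the earlier instance on the other core, the two steps cannot be told apart: the same change on two cores in this assay, a 1.4-fold lower number (0.14 log units; within the scatter) from compound 2 to compound 3 and a 1.4-fold higher number (0.16 log units; within the scatter) from compound 1 to compound 4, 2.0-fold (0.29 log units) apart, within the scatter of two such steps. This shows that on both cores the change stays within the scatter, and that nothing here marks the core as mattering; it does not show that the change carries over as a rule, since two steps of this small size can neither establish a shared effect nor exclude a dependence on the core or on where the group sits.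

On these data alone, all four compounds carry a hydroxyl on one aromatic ring and only amino or methoxy on the other, so whether the series can move beyond the scatter at all remains open. A longer chain such as ethoxy or butoxy, a carboxylic acid, or a halogen such as fluorine or chlorine in the same place would test this, as would a compound in which the hydroxyl is replaced.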